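Two Chloropyrimidinyl Isomers and Their Solubility

The source may hold more compounds than are shown below. What is called first, only, known or untested is meant among the compounds shown, and "the series" means these compounds.

Of the compounds shown here, three have been measured in a physicochemical assay for solubility, read by HPLC, in phosphate buffer, with a stated time of 24 h, at pH 7.4; a higher number here means a more soluble compound, a lower number a less soluble compound. Compound 1 `Clc1ccc2c(NCCNc3nccc(Cl)n3)ccnc2c1` gives 900 nM, compound 3 `Clc1ccc2c(NCCNc3ccnc(Cl)n3)ccnc2c1` gives 680 nM, and compound 2 `Clc1ccc2c(NCCCNc3nccc(Cl)n3)ccnc2c1` gives 400 nM. Compound 3 differs from compound 1 by 2-chloropyrimidin-4-yl in place of 4-chloropyrimidin-2-yl on an amine nitrogen, and the resulting step, a 1.3-fold lower number from compound 1 to compound 3 (0.12 log units; within the scatter), lies within the scatter. The difference between the cores of compound 1 and compound 2 is not broken down here; their values differ beyond the scatter, whereas the values of compound 2 and compound 3 lie within the scatter of each other.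

Compound 4 `Clc1ccc2c(NCCCNc3ccnc(Cl)n3)ccnc2c1` has not yet been measured. It differs from compound 2 by 2-chloropyrimidin-4-yl in place of 4-chloropyrimidin-2-yl on an amine nitrogen, the same change that separates compound 3 from compound 1, made on the same kind of amine nitrogen. The earlier step, a 1.3-fold lower number from compound 1 to compound 3 (0.12 log units; within the scatter), was small. A step of similar size is expected here, a 1.3-fold lower number from compound 2 to compound 4 (0.10 log units; within the scatter), an expectation that rests on that one measured pair alone. Compound 4 is accordingly estimated at 320 nM, with a likely range from 120 nM to 800 nM.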

Compound 4, solubility: 600 nM
Estimate against measurement, compound 4: 1.9-fold (0.27 log units) below; the range from low to high includes it.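

In this assay, putting 2-chloropyrimidin-4-yl in place of 4-chloropyrimidin-2-yl on the amine nitrogen gives a 1.5-fold higher number from compound 2 to compound 4 (0.18 log units; within the scatter), and the same change on the other core gives a 1.3-fold lower number from compound 1 to compound 3 (0.12 log units; within the scatter). Both steps lie within the scatter, so on these two cores the change leaves no readable difference, and the opposite signs of the two steps give no direction that could be carried from one core to the other. This rests on two pairs alone and does not show that the change would stay this small on any further core, and nothing shown here bears on why either step has the size it has.

The compounds shown leave open whether the step would stay within the scatter on a core with a longer chain, or on one carrying a carboxylic acid or a further amine. They also leave open what a methoxy group in place of the chlorine on the pyrimidine would do.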